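Cyclohexyl for Isobutyl on the Amide Nitrogen of Compound 1

The source may hold more compounds than are shown below. What is called first, only, known or untested is meant among the compounds shown, and "the series" means these compounds.

Compound 1 `CC(C)CNC(=O)[C@H](C)NC(=O)[C@@]1(Cc2ccccc2)CCN1C(=O)OCc1ccccc1`: > 100000 nM in an ADME assay on HELF cells (Homo sapiens) for cytotoxicity, with a stated time of 3 days; on this read-out higher numbers stand for lower toxicity in this test and lower numbers for higher toxicity in this test
Compound 2 `C[C@H](NC(=O)[C@]1(Cc2ccccc2)CCN1C(=O)Oc1cccc2ccccc12)C(N)=O`: > 100000 nM in this assay
Compound 3 `CC(C)C[C@H](NC(=O)[C@]1(Cc2ccccc2)CCN1C(=O)OCc1ccccc1)C(N)=O`: 100000 nM in this assay

The value given for compound 1 in this assay is a limit of the assay, not a number. The value for compound 2 is likewise a limit. Compound 3 gives a number sitting at the same concentration as those limits. So compound 1 stands where the whole series stands: at the limit of > 100000 nM in this assay, at which 2 of the 3 values shown sit, with no compound showing measurable toxicity below it.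

The unmeasured compound 4 `C[C@H](NC(=O)[C@@]1(Cc2ccccc2)CCN1C(=O)OCc1ccccc1)C(=O)NC1CCCCC1` differs from compound 1 by cyclohexyl in place of isobutyl on an amide-type nitrogen. Among the measured compounds shown here, no step between measured compounds is available to guide the size; the step of a number no higher from compound 1 to compound 4 (the limit leaves the size open) is expected to be none beyond the scatter. Compound 4 is therefore estimated at 100000 nM, within 50000 nM to 200000 nM, most likely reported again as a limit.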

Compound 4, minimum cytotoxic concentration: 100000 nM
For compound 4 middle estimate and measured number coincide at the digits printed, within the range that was stated.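

With cyclohexyl in place of isobutyl on the amide-type nitrogen, a carbon-only six-membered ring now sits at this position, and in this assay compound 4 gives 100000 nM as a number, at the same concentration as the rest of the series: the limit of > 100000 nM in this assay, at which 2 of the 4 values shown sit. Compound 1 gives > 100000 nM, which is a limit of the assay and not a number. The step is therefore a number no higher from compound 1 to compound 4 (the limit leaves the size open), and its size cannot be read. The compounds shown leave open whether an amine, a carboxylic acid or a longer chain on this nitrogen would give a lower number.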